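The compounds below may be only part of what the source reports. "The series", "measured", "known", "first", "only" and "open" are said of these compounds alone.

In an ADME assay on microsomes from liver (Homo sapiens) for metabolic stability, tested at 2.5 uM (on this read-out higher numbers stand for fast clearance and lower numbers for slow clearance), compound 3 `O=S(=O)(c1ccc(F)c(Cl)c1)c1cnc2c(F)cccc2c1-c1cccc(F)c1` gives 1.23 mL/min. Among the three compounds measured so far, that is the second highest number. Compound 1 `O=S(=O)(c1ccc(F)cc1)c1cnc2c(F)cccc2c1-c1cccc(F)c1` gives 1.56 mL/min, and compound 2 `O=S(=O)(c1cc(Cl)cc(Cl)c1)c1cnc2c(F)cccc2c1-c1ccccc1F` gives 0.44 mL/min, the lowest of the three. Compound 4 `O=S(=O)(c1cc(Cl)cc(Cl)c1)c1cnc2c(F)cccc2c1-c1cccc(F)c1` has not yet been measured. It differs from compound 3 in one place: 3,5-dichlorophenyl in place of 3-chloro-4-fluorophenyl on a sulfonyl sulfur. Among the compounds with values here, only one measured step changes a single place, and that is a 1.3-fold lower number from compound 1 to compound 3 (0.10 log units; within the scatter), a change of a different kind, so it says little about the move to compound 4. Compound 2 carries the same 3,5-dichlorophenyl on the sulfonyl sulfur, but it also differs from compound 4 elsewhere, so its value can only hint. Because compound 2 gives 0.44 mL/min in this assay, a lower number than compound 3 is expected, and the expected step is a 1.8-fold lower number from compound 3 to compound 4 (0.24 log units; within the scatter). Compound 4 is therefore estimated to give 0.7 mL/min, with a range from 0.35 mL/min to 1.4 mL/min.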

Compound 4, intrinsic clearance in a liver preparation (reported as CLH), per the amount of preparation that the assay uses: 1.08 mL/min
For compound 4 the middle estimate is 1.5-fold (0.19 log units) below the measured one; measured number inside the range.
By their numbers in this assay, from the lowest: compound 2; then compounds 4, 3 and 1 (each within the scatter of the next).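

Swapping the aryl group on the sulfonyl sulfur barely registers in this assay: 3,5-dichlorophenyl in place of 3-chloro-4-fluorophenyl gives a step within the scatter (a 1.1-fold lower number from compound 3 to compound 4 (0.06 log units; within the scatter)), and 3,5-dichlorophenyl in place of 4-fluorophenyl does too (a 1.4-fold lower number from compound 1 to compound 4 (0.16 log units; within the scatter)). Within the data shown here, the only step here beyond the scatter comes from the other place, with 3-fluorophenyl in place of 2-fluorophenyl on an aromatic carbon (a 2.5-fold higher number from compound 2 to compound 4 (0.39 log units; beyond the scatter)), and that step is modest. No measurement offered here accounts for either result.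

Every group shown on the sulfonyl sulfur is a halogen-bearing phenyl ring, so what a phenyl carrying a methoxy group or an amine would give there remains open. Also open, on these data alone, is whether the fluorophenyl step holds with a different group on the sulfonyl sulfur.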